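From Benzyloxycarbonylamino to Azido: a Stability Expectation

The compounds below may be only part of what the source reports. "The series", "measured", "known", "first", "only" and "open" are said of these compounds alone.

Compound 1 `COc1ccc(-c2c(C)nc3c(N4CC[C@@H](NC(=O)OCc5ccccc5)C4)cc(C)nn23)cc1OC`: in an ADME assay on microsomes from liver (Homo sapiens) for metabolic stability, read by LC-MS, with NADPH named in the record, with a stated time of 60 min, tested at 1 uM, in the absence of a further agent (a lower number here means that less of the compound is left, a higher number that more of the compound is left), compound 1 gives > 95%, which is a limit of the assay and not a number.
Compound 2 `COc1ccc(-c2c(C)nc3c(N4CCN(C(=O)OC(C)(C)C)C4)cc(C)nn23)cc1OC`: in this assay compound 2 gives > 95%, which is likewise a limit of the assay.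

Among the measured compounds shown here, compound 1 therefore stands only at a limit in this assay, and the one further value shown is a limit too; both values sit at the limit of > 95% in this assay, at which 2 of the 2 values shown sit. For the measured compounds named here, nothing in these two results separates compound 1 from compound 2, and no step between measured compounds is available from which the size of a change could be read.

Compound 3 `COc1ccc(-c2c(C)nc3c(N4CC[C@@H](N=[N+]=[N-])C4)cc(C)nn23)cc1OC` has not yet been measured. It differs from compound 1 in one place: azido in place of (benzyloxycarbonyl)amino on a saturated ring carbon.

Going by the values given here, with no measured step to lean on, the expectation rests on the high standing of compound 1 alone. In this assay the expected step is small, at most a modest fall, and it may well stay within the scatter: a number at least 5 percentage points lower from compound 1 to compound 3 (that floor lies within the scatter) is the step the estimate implies. Compound 3 is expected to give about 90%, between 70% and 98%.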

Compound 3, percent of the compound remaining: > 95%
Compound 3 ended at the assay's limit (the forecaster's own chance of this, stated with the estimate: 0.5%); middle value at least 5 percentage points away from the limit.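

In this assay compound 3 gives > 95%, which is a limit of the assay and not a number. Compound 1 also stands at a limit, so no step can be read between compound 1 and compound 3. The compounds shown leave open whether azido in place of (benzyloxycarbonyl)amino changes the read-out at all, since all the values sit together: the limit of > 95% in this assay, at which 3 of the 3 values shown sit.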